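The compounds below may be only part of what the source reports. "The series", "measured", "known", "first", "only" and "open" are said of these compounds alone.

Measured so far in a functional assay on NCI-H292 cells (Homo sapiens) for cytotoxicity, read by MTT assay, with a stated time of 72 h, tested at 2.5 ug/mL; a lower number here means less inhibition of growth, a higher number more inhibition of growth at the concentration tested:
compound 1 `O=C1NC(=S)/C(=C/c2ccc(Cl)cc2)S1` gives 28.6%
compound 2 `O=C1NC(=S)/C(=C/c2cccc(Cl)c2)S1` gives 11.2%
compound 3 `O=C1NC(=S)/C(=C/c2cccc(F)c2)S1` gives 3.43%

Compound 2 stands second highest of the three numbers in this assay. Its nearest neighbour is compound 3, and the step of a number 7.8 percentage points lower from compound 2 to compound 3 (within the scatter) is within the scatter, so the two cannot be told apart. Compound 1 sits further off, above compound 2 by more than the scatter.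

Compound 4 `O=C1NC(=S)/C(=C/c2ccc(Cl)c(Cl)c2)S1` is reached from compound 2 by one change: chloro in place of hydrogen on an aromatic carbon. Going by the values given here, the only measured step, from compound 2 to compound 3, swapped one halogen for another and stayed within the scatter; it says nothing about adding a second chloro group. What does bear on it is the pair compound 1 and compound 2: their two values show that a single chloro group placed as in compound 1 goes with a higher number than one placed as in compound 2, and compound 4 carries both placements. Among the compounds with values here, the number for compound 4 is therefore expected to rise, by roughly a number 18.8 percentage points higher from compound 2 to compound 4 (beyond the scatter), though with wide uncertainty since only one such pair exists. The estimate for compound 4 is 30%, with a range from 10% to 55%.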

Compound 4, percent growth inhibition at one concentration: 19.4%
Beside the measured number, compound 4's estimate is 10.6 percentage points above it; the measured number falls inside the stated range.
By their numbers in this assay, from the lowest: compounds 3, 2, 4 and 1 (each within the scatter of the next, the first and the last beyond it).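

In this assay, a chloro group in place of hydrogen on the aromatic carbon ortho to a chloro group and para to a group of 8 heavy atoms gives a number 8.2 percentage points higher from compound 2 to compound 4 (within the scatter), and the same comparison from the other single-chloro compound gives a number 9.2 percentage points lower from compound 1 to compound 4 (within the scatter). Compound 4 therefore cannot be told apart from either compound 2 or compound 1, even though those two differ from each other by more than the scatter, so the two chloro placements together do not give a number beyond that of compound 1. No measurement here offers an explanation for this result.

On these data alone, whether a methoxy group or an amine on this same aromatic carbon would move the number beyond the scatter remains open. So does whether a carboxylic acid there would do so.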